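Changing the group on sulfur in a shared core

The source may hold more compounds than are shown below. What is called first, only, known or untested is meant among the compounds shown, and "the series" means these compounds.

Of the compounds shown here, three with a shared core have numbers so far in a functional assay on HT cells (Homo sapiens) for antiproliferative activity, read by fluorescence, with a stated time of 72 h; a higher number here means a weaker inhibitor of growth, a lower number a stronger inhibitor of growth. Compound 1 `CC(C)c1n[nH]c2c(NCc3ccc(-c4ccccn4)cc3)nc(SCC(O)CN3CCNCC3)nc12` gives 332 nM, compound 2 `CC(C)c1n[nH]c2c(NCc3ccc(-c4ccccn4)cc3)nc(SCC(C)(C)O)nc12` gives 507 nM, and compound 3 `CC(C)c1n[nH]c2c(NCc3ccc(-c4ccccn4)cc3)nc(SCCNC(=N)N)nc12` gives 390 nM. Compound 3 therefore stands within the usual scatter of both others, and no order can be read among the three.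

Compound 4 `CC(C)c1n[nH]c2c(NCc3ccc(-c4ccccn4)cc3)nc(SC3CCCCC3O)nc12` has not been measured. Its change from compound 3 is a group of 7 heavy atoms (6 carbon, 1 oxygen; one six-membered non-aromatic ring of carbon only) in place of a group of 6 heavy atoms (3 carbon, 3 nitrogen; no ring), on a sulfur, and the group that enters is 2-hydroxycyclohexyl.

Going by the values given here, three measured steps bear on this, as each alters the group carried on the sulfur: a 1.5-fold higher number from compound 1 to compound 2 (0.18 log units; within the scatter), a 1.2-fold higher number from compound 1 to compound 3 (0.07 log units; within the scatter) and a 1.3-fold lower number from compound 2 to compound 3 (0.11 log units; within the scatter). All three are small, although the groups differ considerably. Among the compounds with values here, none of the measured compounds has a ring of carbon only in this place, so the range must stay wide.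

In this assay, no step beyond the scatter is expected, and no direction can be favoured. The expected step is a 1.0-fold higher number from compound 3 to compound 4 (0.01 log units; within the scatter). For compound 4 the estimated value is 400 nM, within an expected range of 150 nM to 1000 nM.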

Compound 4, concentration for 50% growth inhibition: 636 nM
Estimate against measurement, compound 4: 1.6-fold (0.20 log units) below, and the stated range covers the measured number.
By their numbers in this assay, from the lowest: compounds 1, 3, 2 and 4 (each within the scatter of the next).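

In this assay this sulfur can carry a ring of carbon only, 2-hydroxycyclohexyl, and the result stays within the scatter of all three earlier compounds. The step from the chain without a hydroxyl is small (a 1.6-fold higher number from compound 3 to compound 4 (0.21 log units; within the scatter)), the step from 2-hydroxy-2-methylpropyl is small (a 1.3-fold higher number from compound 2 to compound 4 (0.10 log units; within the scatter)), and so is the step from 2-hydroxy-3-(piperazin-1-yl)propyl (a 1.9-fold higher number from compound 1 to compound 4 (0.28 log units; within the scatter)). Nothing measured here gives a reason for these small steps.

The compounds shown leave open whether a carboxylic acid, a long unbranched carbon chain or a plain cyclohexyl ring on this sulfur would also stay within the scatter. All four compounds share the same core, so they also say nothing about changes anywhere else on it.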